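This account rests on a few compounds, and the source may have more. Where it says the series, first, only, none or still open, it means among the compounds named here.

Three compounds of this series carry the same core and differ only in the straight chain on the aromatic ring. Compound 1 `CCCCc1ccc(-c2c(C)[nH]c(=O)n2C)cc1` gives 0.1 mg/kg in a functional assay on the whole organism with Rattus norvegicus as the target; on this read-out higher numbers stand for an effect only at larger amounts of compound and lower numbers for an effect already at smaller amounts. Compound 2 `CCCCCCc1ccc(-c2c(C)[nH]c(=O)n2C)cc1` gives 0.3 mg/kg in this assay, and compound 3 `CCCCCCCc1ccc(-c2c(C)[nH]c(=O)n2C)cc1` gives 30 mg/kg in this assay, the highest of the three numbers. Each lengthening of the chain has moved the number upward: a 3.0-fold higher number from compound 1 to compound 2 (0.48 log units; beyond the scatter), a 100-fold higher number from compound 2 to compound 3 (2.00 log units; beyond the scatter), and over both at once a 300-fold higher number from compound 1 to compound 3 (2.48 log units; beyond the scatter). The last of the measured steps, one carbon added to a chain that was already long, was the largest.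

Compound 4 `CCCCCCCCCCc1ccc(-c2c(C)[nH]c(=O)n2C)cc1` continues the same line, with propyl in place of hydrogen on a saturated chain carbon, seven bonds along the chain from an aromatic carbon. The step from compound 3 to compound 4 resembles the step from compound 2 to compound 3 in kind but adds three carbons rather than one, so a further rise in the number is expected, and the measurement may return only a limit if the effect is not reached at the largest amount given. The expected step is a 10-fold higher number from compound 3 to compound 4 (1.00 log units; beyond the scatter). For compound 4 the estimate in this assay is 300 mg/kg, with a range from 60 mg/kg to 1500 mg/kg.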

Compound 4, minimum effective dose: 0.3 mg/kg
Compound 4: the middle estimate sits 1000-fold (3.00 log units) above what was measured; measured number below the stated range.
By their numbers in this assay, from the lowest: compound 1; then compounds 2 and 4 (each within the scatter of the next); then compound 3.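

In this assay, for the compounds shown here, adding propyl at this place on the chain reverses the earlier climb: the result is a 100-fold lower number from compound 3 to compound 4 (2.00 log units; beyond the scatter) and the rise seen through compound 1, compound 2 and compound 3 does not simply go on, with compound 4 as the one compound against that trend. The longest chain shown instead returns to the range of the shorter chains, with no change at the digits printed from compound 2 to compound 4 (within the scatter) and a 3.0-fold higher number from compound 1 to compound 4 (0.48 log units; beyond the scatter), so the change from hexyl-length chains onward is not a steady loss and compound 3 stands alone with the highest number of the four. Nothing available here accounts for why compound 3 sits so far from the compounds on either side of it in chain length.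

The compounds shown leave open whether compound 3 is a single high point or part of a broader band, which octyl and nonyl chains on the same core would help to settle. They also leave open whether the low number of compound 4 would hold with a branched chain of similar size, or with a chain ending in an amine or a carboxylic acid.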